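Methyl on the amino group of compound 2

The source may report more compounds than this note shows. Statements on the series, on what has been measured and on what is new or still open speak of the compounds shown alone.

Measured so far:
- compound 1 (`CCc1ccc(Cl)cc1-n1cc(-c2ncnn3cccc23)cc1C(N)=O`): 12400 nM
- compound 2 (`CCc1ccc(Cl)cc1-n1cc(-c2cc(N)ncn2)cc1C(N)=O`): 45900 nM

In an ADME assay on the whole organism (strain Balb) for pharmacokinetics, with Mus musculus as the target, read by LC-MS, at a dose of 10 mg/kg by the intravenous route (on this read-out higher numbers stand for higher exposure at the dose given and lower numbers for lower exposure), compound 2 gives 45900 nM and holds the higher of the two numbers. Compound 1 gives 12400 nM and lies below compound 2 by more than the usual scatter of repeated measurements.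

The next structure is compound 3 (`CCc1ccc(Cl)cc1-n1cc(-c2cc(NC)ncn2)cc1C(N)=O`). It has methyl in place of hydrogen on a nitrogen on an aromatic ring, so amino becomes methylamino and the 6-aminopyrimidin-4-yl group becomes 6-(methylamino)pyrimidin-4-yl (methyl in place of hydrogen on a nitrogen on an aromatic ring). The rest of the structure stays as in compound 2.

Going by the values given here, no pair of measured compounds shows this change, so the series offers no direct precedent for its size, and the expectation rests on the structural change alone. The added methyl is a single heavy atom, and a modest fall in this assay is expected (a 1.5-fold lower number from compound 2 to compound 3 (0.18 log units; within the scatter)), most likely within the scatter. For compound 3 the expected value is 30000 nM (estimated range 12000 nM to 70000 nM).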

Compound 3, maximal plasma concentration in the Mus musculus assay: 32000 nM
Estimate against measurement, compound 3: 1.1-fold (0.03 log units) below, and the stated range covers the measured number.
By their numbers in the Mus musculus assay, from the lowest: compound 1; then compounds 3 and 2 (each within the scatter of the next).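

Compound 3 gives the series its first step that differs in one place: in the Mus musculus assay the change from amino to methylamino gives a 1.4-fold lower number from compound 2 to compound 3 (0.16 log units; within the scatter) and so leaves exposure at this position unresolved from that of compound 2. In a physicochemical assay for solubility, at pH 7 (a higher number here means a more soluble compound, a lower number a less soluble compound), the same methyl in place of hydrogen gives a 1.2-fold lower number from compound 2 to compound 3 (0.06 log units; within the scatter), with compound 2 at 128000 nM and compound 3 at 111000 nM, so neither read-out separates the two compounds, and this nitrogen on an aromatic ring tolerates one added carbon without a step beyond the scatter in either. The data shown offer no measured basis for explaining either read-out.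

This single pair does not show how far the tolerance extends on this nitrogen: an ethyl group, a cyclopropyl group, a second methyl giving dimethylamino, or an acetyl group could still give a step beyond the scatter. From the compounds shown here alone, whether methyl has the same outcome elsewhere, for example in place of the amide hydrogen of the carboxamide, also stays open.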